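Pyridin-3-yl in place of pyridin-4-yl

A few compounds are considered here, and "the series" means these few. Any claim that something is new, unique, unknown or untested is made for them only; others in the source may bear on it.

Values in a functional assay on HT-29 cells (Homo sapiens) for antiproliferative activity (on this read-out lower numbers stand for stronger inhibition of growth and higher numbers for weaker inhibition of growth), so far
compound 1 `c1ccc(-c2cc(-c3cccnc3)nc(-c3ccccn3)c2)cc1` gives 0.33 ug/mL
compound 2 `c1ccc(-c2cc(-c3ccsc3)cc(-c3cccnc3)n2)nc1` gives 0.36 ug/mL
compound 3 `c1ccc(-c2cc(-c3cccs3)cc(-c3ccncc3)n2)nc1` gives 0.52 ug/mL

Compound 3 at 0.52 ug/mL lies within the scatter of both other compounds and holds no distinct place among them. Compound 4 `c1ccc(-c2cc(-c3cccs3)cc(-c3cccnc3)n2)nc1` differs from it by pyridin-3-yl in place of pyridin-4-yl on an aromatic carbon on an aromatic carbon next to the ring nitrogen. Within the data shown here, no measured step tests this swap directly. The only one available a 1.1-fold higher number from compound 1 to compound 2 (0.04 log units; within the scatter) exchanges another group and stays within the scatter. Compound 2 carries pyridin-3-yl and gives 0.36 ug/mL so no step beyond the scatter is expected in this assay for this swap. The estimated 1.3-fold lower number from compound 3 to compound 4 (0.11 log units; within the scatter) is expected to stay within the scatter. Compound 4 is expected at 0.4 ug/mL with an estimated range from 0.2 ug/mL to 0.8 ug/mL in this read-out.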

Compound 4, concentration for 50% growth inhibition: 0.19 ug/mL
Compound 4: the middle estimate sits 2.1-fold (0.32 log units) above what was measured; measured number outside the range, below it.
By their numbers in this assay, from the lowest: compounds 4, 1, 2 and 3 (each within the scatter of the next, the first and the last beyond it).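

Among these compounds, with thiophen-2-yl held fixed in this assay, pyridin-3-yl in place of pyridin-4-yl gives a 2.7-fold lower number from compound 3 to compound 4 (0.44 log units; beyond the scatter) and so makes this the first step to pass beyond the scatter, showing that this position responds to a shift of the pyridine ring nitrogen. Thiophen-2-yl in place of thiophen-3-yl gives a 1.9-fold lower number from compound 2 to compound 4 (0.28 log units; within the scatter) and thiophen-2-yl in place of phenyl gives a 1.7-fold lower number from compound 1 to compound 4 (0.24 log units; within the scatter) and neither step separates these rings. No data on hand account for the pyridine step. Open, on these data alone, is whether an amine or a carboxylic acid on the pyridin-3-yl ring would keep or lose this growth inhibition.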